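A few compounds are considered here, and "the series" means these few. Any claim that something is new, unique, unknown or untested is made for them only; others in the source may bear on it.

Among the compounds with values here, in a functional assay on HCC827 cells (Homo sapiens) for antiproliferative activity, read by MTT assay, with a stated time of 72 h (a higher number here means a weaker inhibitor, a lower number a stronger inhibitor), compound 1 `CN1CCN(c2ccc(Nc3ncc4nc(Nc5ccc(F)cc5)n([C@H]5CCCN(C(=O)CO)C5)c4n3)cc2)CC1` gives 1.8 nM, the lowest of the three numbers so far. Compound 2 `CN1CCN(c2ccc(Nc3ncc4nc(Nc5ccccc5)n([C@H]5CCN(C(=O)OC(C)(C)C)C5)c4n3)cc2)CC1` gives 110 nM and compound 3 `CN1CCN(c2ccc(Nc3ncc4nc(Nc5ccccc5)n([C@H]5CCNC5)c4n3)cc2)CC1` gives 530 nM, and both lie beyond the scatter from compound 1. The next candidate is compound 4 `CN1CCN(c2ccc(Nc3ncc4nc(Nc5ccc(F)cc5)n([C@@H]5CCN(S(=O)(=O)C6CC6)C5)c4n3)cc2)CC1`. It keeps the (4-fluorophenyl)amino group of compound 1 but replaces the group on the aromatic nitrogen: 1-(cyclopropylsulfonyl)pyrrolidin-3-yl in place of 1-((hydroxymethyl)carbonyl)piperidin-3-yl on an aromatic nitrogen.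

Within the data shown here, only one measured step bears on this change, and it does so indirectly. That step, a 4.8-fold higher number from compound 2 to compound 3 (0.68 log units; beyond the scatter), is modest and shows that the group on the ring nitrogen can move the number beyond the scatter. Compounds 2 and 3 share the five-membered non-aromatic ring of compound 4, but they carry a plain phenyl in place of the 4-fluorophenyl, and neither has a cyclopropylsulfonyl group. Among the measured compounds shown here, no measured step therefore isolates the change of ring size or of the group on the ring nitrogen.

A move to a higher number is expected, probably larger than the scatter, though the values of compounds 2 and 3 may overstate it. The expected change is an 11-fold higher number from compound 1 to compound 4 (1.05 log units; beyond the scatter). For compound 4 the estimated value is 20 nM, with an expected range from 4 nM to 100 nM.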

Compound 4, half-maximal inhibitory concentration: 2.5 nM
Compound 4: middle estimate off by 8.0-fold (0.90 log units), on the high side; the measured number lies below the stated range.
By their numbers in this assay, from the lowest: compounds 1 and 4 (each within the scatter of the next); then compound 2; then compound 3.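

In this assay the exchange of 1-((hydroxymethyl)carbonyl)piperidin-3-yl for 1-(cyclopropylsulfonyl)pyrrolidin-3-yl on an aromatic nitrogen gives a 1.4-fold higher number from compound 1 to compound 4 (0.14 log units; within the scatter) and so does not separate the two groups. Within the data shown here, the earlier compounds showed only that a change on the nitrogen of the five-membered ring can move the number, and none of them carried the (4-fluorophenyl)amino group, whereas this pair holds that group and the rest of the core fixed and shows that this position accepts a different ring size, a cyclopropylsulfonyl group and one hydrogen-bond donor fewer, all at once, without a step beyond the scatter. Nothing shown here gives a reason why these two groups lie so close together in this assay.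

Ring size and the group on the ring nitrogen change together in this pair, so a compound carrying 1-(cyclopropylsulfonyl)piperidin-3-yl would be needed to tell what each contributes alone. As far as these compounds go, it also remains open whether this position would accept a group of a different kind on the ring nitrogen, such as a carboxylic acid or a longer chain ending in an amine.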